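Aromatic Ring to Saturated Ring on the Amide Nitrogen

This account rests on a few compounds, and the source may have more. Where it says the series, first, only, none or still open, it means among the compounds named here.

Compound 1, `Cc1ccc(S(=O)(=O)N2C=CNC(=O)[C@H]2CC(=O)N[C@@H]2CCCc3cc(CN4CCCCC4)ccc32)cc1`: 0.115 nM
Compound 2, `Cc1ccc(S(=O)(=O)N2C=CNC(=O)[C@H]2CC(=O)N[C@@H]2CCCc3ccccc32)cc1`: 3.3 nM
Compound 3, `Cc1ccc(S(=O)(=O)N2C=CNC(=O)[C@H]2CC(=O)NC2CCCCC2C)cc1`: not yet measured

Of the two measured compounds, compound 2 stands at the higher number, giving 3.3 nM in an in vitro functional assay on cells for antagonist activity at B1 bradykinin receptor (Homo sapiens), read by luminescence and calcium flux, with a stated time of 2 h; a lower number here means a stronger inhibitor, a higher number a weaker inhibitor. Among the compounds with values here, its only neighbour is compound 1, and the step of a 29-fold higher number from compound 1 to compound 2 (1.46 log units; beyond the scatter) is large and lies beyond the scatter. Compound 3 arises from compound 2 by 2-methylcyclohexyl in place of 1,2,3,4-tetrahydronaphthalen-1-yl on an amide-type nitrogen. Within the data shown here, no measured step touches the amide nitrogen; the one available step concerns the aromatic carbon and bears on this change only by showing how strongly the shared core responds to a single alteration. The new change is a larger rearrangement than that one, replacing an aromatic ring with a saturated one, so a step beyond the scatter toward a higher number is expected. Compound 3 is estimated at 30 nM, within 5 nM to 300 nM. This estimate means an expected 9.1-fold higher number from compound 2 to compound 3 (0.96 log units; beyond the scatter).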

Compound 3, half-maximal inhibitory concentration: 25.9 nM
For compound 3 the middle estimate is 1.2-fold (0.06 log units) above the measured one, and the stated range covers the measured number.
By their numbers in this assay, from the lowest: compound 1; then compound 2; then compound 3.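

In this assay, within the data shown here, replacing 1,2,3,4-tetrahydronaphthalen-1-yl with 2-methylcyclohexyl on the amide-type nitrogen gives a 7.8-fold higher number from compound 2 to compound 3 (0.89 log units; beyond the scatter), the first measured change at this position and one that lies beyond the scatter. Among these compounds, compound 3 still gives 25.9 nM with only one non-aromatic ring in this group, so an aromatic ring here is not essential for inhibition in this pair, though the number is higher without it. Nothing available explains the size of this step.

The change removes an aromatic ring, three heavy atoms and a defined stereocentre together, so the compounds shown do not separate these contributions. Going by these compounds, it also remains open how an unsubstituted cyclohexyl group would compare, or whether a piperidin-1-ylmethyl group on the cyclohexyl ring would lower the number as it does on the shared core of compound 1.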